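This account rests on a few compounds, and the source may have more. Where it says the series, first, only, none or still open, it means among the compounds named here.

Measured so far in a functional assay on UACC-62 cells (Homo sapiens); a lower number here means a stronger inhibitor of growth, a higher number a weaker inhibitor of growth:
Compound 1 `O=S(=O)(/C=C/c1ccc(C(F)(F)F)cc1F)Cc1ccc(Nc2ncnc3cc(Cl)ccc23)cc1` gives > 100000 nM as a limit of the assay.
Compound 2 `O=S(=O)(/C=C/c1ccc(F)cc1Cl)Cc1ccc(Nc2ncnc3cc(Cl)ccc23)cc1` gives 72000 nM as a number.

Going by the values given here, compound 2 therefore holds the only number so far, the other value being the limit noted in the limit of > 100000 nM in this assay, at which 1 of the 2 values shown sits, for compound 1. Compound 3 `O=S(=O)(/C=C/c1ccc(F)cc1F)Cc1ccc(Nc2ncnc3cc(Cl)ccc23)cc1` differs from compound 2 by fluoro in place of chloro on an aromatic carbon with fluoro in place of chloro on an aromatic carbon, ortho to a large group. Among the compounds with values here, the single measured step of an at least 1.3-fold lower number from compound 1 to compound 2 (0.14 log units; that floor lies within the scatter) also changes this ring and shows nothing beyond the scatter, so no step beyond the scatter is expected in this assay here. The estimated step is a 1.0-fold higher number from compound 2 to compound 3 (0.02 log units; within the scatter) and no more than that. Compound 3 is expected at 75000 nM with an estimated range from 35000 nM to 100000 nM in this assay.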

Compound 3, concentration for 50% growth inhibition: > 100000 nM
Compound 3 gave a limit, no number; the forecaster's own chance of this, stated with the estimate: 30%; middle value at least 1.3-fold (0.12 log units) away from the limit.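

In this assay, fluoro in place of chloro on the aromatic carbon ortho to a large group gives an at least 1.3-fold higher number from compound 2 to compound 3 (0.14 log units; that floor lies within the scatter). On these data alone, compound 3 reads as a limit of the assay, so the true size of this step stays unknown, and little of the series gives a readable number: the limit of > 100000 nM in this assay, at which 2 of the 3 values shown sit. Compound 1 and compound 3 both stand as limits, and the step between them cannot be read.

As far as these compounds go, whether an amine, a methoxy group or a carboxylic acid on this carbon would give a readable number stays open. So does whether any change here gives a step beyond the scatter.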